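Cytotoxicity of a benzamide series: the step to compound 3

A few compounds are considered here, and "the series" means these few. Any claim that something is new, unique, unknown or untested is made for them only; others in the source may bear on it.

Compound 1 `Cc1ccc(NC(=O)c2cccc(C(F)(F)F)c2)cc1-n1cc(-c2cnc3cccnn23)cn1`: 40300 nM
Compound 2 `Cc1ccc(NC(=O)c2ccc(C(F)(F)F)cc2)cc1-n1cc(-c2cnc3cccnn23)cn1`: > 80000 nM

In an ADME assay on HEK-293T cells (Homo sapiens) for cytotoxicity, read by CCK-8 assay, with a stated time of 24 h (a lower number here means that less compound is tolerated, a higher number that more compound is tolerated), compound 1 gives 40300 nM. Compound 2 stands only at a limit: in this assay compound 2 gives > 80000 nM, a limit of the assay and not a number (the limit of > 80000 nM in this assay, at which 1 of the 2 values shown sits). Going by the values given here, the single measured step, an at least 1.9-fold higher number from compound 1 to compound 2 (0.29 log units; that floor lies within the scatter), lies within the scatter. Compound 3 `Cc1ccc(NC(=O)c2ccc(F)cc2)cc1-n1cc(-c2cnc3cccnn23)cn1` differs from compound 2 by fluoro in place of trifluoromethyl on an aromatic carbon. Among the compounds with values here, no measured step exchanges the trifluoromethyl itself, so no step beyond the scatter is expected in this assay, in either direction. Compound 3 is therefore estimated at 75000 nM, between 35000 nM and 160000 nM. The expected step is an at least 1.0-fold lower number from compound 2 to compound 3 (0.02 log units; that floor lies within the scatter).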

Compound 3, half-maximal cytotoxic concentration: > 80000 nM
Compound 3: only a limit was reported; the forecaster's own chance of this, stated with the estimate: 50%; middle value at least 1.0-fold (0.02 log units) from the limit.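

In this assay compound 3 gives > 80000 nM, a limit of the assay and not a number, so a fluoro in place of the trifluoromethyl leaves the value at the same limit as compound 2: the limit of > 80000 nM in this assay, at which 2 of the 3 values shown sit. The step between these two compounds cannot be read. Exchanging 3-(trifluoromethyl)phenyl for 4-fluorophenyl on the carbonyl carbon gives an at least 1.9-fold higher number from compound 1 to compound 3 (0.29 log units; that floor lies within the scatter).

Going by these compounds, how much of compound 2 or compound 3 would be tolerated past the limit stays open. Also open, on these data alone, is whether an amine or a carboxylic acid on this aromatic carbon would give a readable number in this assay.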